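This account rests on a few compounds, and the source may have more. Where it says the series, first, only, none or still open, it means among the compounds named here.

Measured in a physicochemical assay for lipophilicity, read by HPLC; on this read-out lower numbers stand for lower lipophilicity and higher numbers for higher lipophilicity:
Compound 1 `Cc1ccsc1C(=CCCN(C)C(CCO)C(=O)N1CCOCC1)c1sccc1C`: 4.75
Compound 2 `Cc1ccsc1C(=CCCN(C)C(CCN)C(=O)NCc1ccc(Cl)cc1)c1sccc1C`: 5.85
Compound 3 `Cc1ccsc1C(=CCCN(C)C(CCN)C(=O)NCc1ccccc1Cl)c1sccc1C`: 6.11

In this assay compound 3 gives 6.11. That value lies within the scatter of compound 2 at 5.85, while compound 1 stands clearly lower at 4.75.

The next compound, compound 4 `Cc1ccsc1C(=CCCN(C)C(CCO)C(=O)NCc1ccccc1Cl)c1sccc1C`, keeps the 2-chlorophenyl group of compound 3 but has hydroxy in place of amino on a saturated chain carbon, three bonds along the chain from an amine nitrogen and a carbonyl carbon.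

Going by the values given here, the only single-place comparison available is a number 0.26 log units higher from compound 2 to compound 3 (within the scatter). It concerns 2-chlorophenyl in place of 4-chlorophenyl, so it does not address this exchange. Compound 1 carries the same hydroxy, but its amide part also differs from that of compound 3. Among the compounds with values here, the gap between those two compounds therefore cannot be assigned to the hydroxy alone, and no measured pair isolates amino against hydroxy.

With so little direct evidence, the expected change is small and the uncertainty wide. The estimated step is a number 0.09 log units higher from compound 3 to compound 4 (within the scatter), and no shift beyond the scatter is expected. For compound 4 the estimate is 6.2, with an expected range from 5.5 to 6.9.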

Compound 4, partition coefficient: 6.23
Compound 4: middle estimate off by 0.03 log units, on the low side; low and high end bracket the measured number.
By their numbers in this assay, from the lowest: compound 1; then compounds 2, 3 and 4 (each within the scatter of the next, the first and the last beyond it).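

In this assay, going by these compounds alone, the exchange of amino for hydroxy on a saturated chain carbon, three bonds along the chain from an amine nitrogen and a carbonyl carbon, gives a number 0.12 log units higher from compound 3 to compound 4 (within the scatter) and so, for the first time in this set, is seen on its own. With hydroxy held fixed, (2-chlorobenzyl)amino in place of morpholin-4-yl on a carbonyl carbon gives a number 1.48 log units higher from compound 1 to compound 4 (beyond the scatter) and is the only single-place step shown that lies beyond the scatter. Among these compounds, then, the read-out moves clearly with the change on the carbonyl carbon and stays within its usual spread for the change on the chain. No measurement is at hand that would explain either step.

From the compounds shown here alone, the amino and hydroxy pair is known only alongside the (2-chlorobenzyl)amino group, so it remains open whether the two would also lie this close with morpholin-4-yl on the carbonyl carbon. Going by these compounds, it is also open whether a methoxy group or a carboxylic acid on the same chain carbon, or a longer chain carrying the hydroxy, would stay within the scatter of compound 4.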